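Methoxy for Trifluoromethoxy on a Weakly Antiproliferative Series

This account rests on a few compounds, and the source may have more. Where it says the series, first, only, none or still open, it means among the compounds named here.

Of the compounds shown here, three have so far been measured in a functional assay on A549 cells (Homo sapiens) for antiproliferative activity, read by MTT assay; on this read-out higher numbers stand for weaker inhibition and lower numbers for stronger inhibition. Compound 1 `COc1ccc2nc(N(Cc3cc(-c4ccc(OC(F)(F)F)cc4)no3)c3nc4ccc(F)cc4s3)sc2c1` gives 37100 nM. Compound 2 `COc1ccc(-c2cc(CN(c3nc4ccc(F)cc4s3)c3nc4ccc(OC)cc4s3)on2)cc1` gives 38800 nM; it differs from compound 1 by methyl in place of trifluoromethyl on an oxygen on an aromatic ring, and that change produced a 1.0-fold higher number from compound 1 to compound 2 (0.02 log units; within the scatter). Compound 3 `FC(F)(F)Oc1ccc(-c2cc(CN(c3ncccn3)c3nc4ccccc4s3)on2)cc1` gives 31800 nM; the difference between its core and the core of compound 1 is not broken down here, and its number lies within the scatter of both other values, so no order among the three compounds can be claimed.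

Compound 4 `COc1ccc(-c2cc(CN(c3ncccn3)c3nc4ccccc4s3)on2)cc1` has not yet been measured. It differs from compound 3 by methyl in place of trifluoromethyl on an oxygen on an aromatic ring, the same change at the same place that separates compound 1 from compound 2. Because that earlier change gave a 1.0-fold higher number from compound 1 to compound 2 (0.02 log units; within the scatter), a step of similar size is expected here, and the expectation rests on that one pair alone. The expected step is a 1.0-fold higher number from compound 3 to compound 4 (0.02 log units; within the scatter). Compound 4 is estimated at 33000 nM in this assay, with an expected range from 16000 nM to 70000 nM.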

Compound 4, half-maximal inhibitory concentration: 30500 nM
Compound 4: the middle estimate sits 1.1-fold (0.03 log units) above what was measured; the range from low to high includes it.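

Methyl in place of trifluoromethyl on the oxygen gave a 1.0-fold lower number from compound 3 to compound 4 (0.02 log units; within the scatter) in this assay, and the two cores carrying this change do not differ in their response: the same change on two cores in this assay, a 1.0-fold higher number (0.02 log units; within the scatter) from compound 1 to compound 2 and a 1.0-fold lower number (0.02 log units; within the scatter) from compound 3 to compound 4, 1.1-fold (0.04 log units) apart, within the scatter of two such steps. On these two cores, then, the step from 4-(trifluoromethoxy)phenyl to 4-methoxyphenyl stays within the scatter each time, and the small step read on the first pair held on the second. This rests on two pairs in one assay, however, so it does not show that the change would behave alike on any other core in the series, nor does it explain why the two steps agree.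

The compounds shown carry only trifluoromethoxy and methoxy at this place, and they leave open what an amine, a carboxylic acid or a longer chain there would do in this assay. They also leave open whether the change would remain this small on a core with a much lower number than those seen here.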